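This account rests on a few compounds, and the source may have more. Where it says the series, first, only, none or still open, it means among the compounds named here.

Working notes on the series.

Three compounds of this set have been run in an ADME assay on liver for metabolic stability, with Liver microsome (Homo sapiens) as the target, read by LC-MS, using microsomes, with a stated time of 5 h; a lower number here means slower removal, a higher number faster removal of the compound. Compound 1 `C[C@]1(O)C[C@](c2cccc(C(F)(F)F)c2)([C@H](O)c2ccccn2)C1` gives 33.3 mL/min/kg. Compound 2 `O[C@H](c1ccccn1)[C@]1(c2cccc(C(F)(F)F)c2)C[C@H](O)C1` gives 133 mL/min/kg. Compound 3 `O[C@H](c1ccccn1)[C@]1(c2ccc(C(F)(F)F)cc2)C[C@@H](O)C1` gives 33.3 mL/min/kg.

Compound 2 and compound 1 differ in one place: methyl in place of hydrogen on a saturated ring carbon. That single change made a 4.0-fold lower number from compound 2 to compound 1 (0.60 log units; beyond the scatter), a step beyond the scatter.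

Compound 3 and compound 2 share the same atoms joined differently; the difference between the two cores is not broken down here. The values of compound 3 and compound 1 agree at the digits printed, so nothing can be said about their order in this assay. Against compound 2, compound 3 sits at a number clearly lower, the gap being beyond the scatter.

Compound 4 `C[C@]1(O)C[C@@](c2ccc(C(F)(F)F)cc2)([C@H](O)c2ccccn2)C1` has not yet been measured. Compared with compound 3 it carries methyl in place of hydrogen on a saturated ring carbon. The place is described in the same words as for the change from compound 2 to compound 1, so this is the same change applied to the core of compound 3 rather than to the core of compound 2.

Within the data shown here, only one earlier instance of this change exists, and it starts from a higher number than compound 3 does. The expectation for compound 4 is a step in the same direction but of smaller size, a 2.2-fold lower number from compound 3 to compound 4 (0.35 log units; beyond the scatter), resting on the lowering seen in a 4.0-fold lower number from compound 2 to compound 1 (0.60 log units; beyond the scatter) and on the low starting point of compound 3 at 33.3 mL/min/kg. Compound 4 is therefore estimated at 15 mL/min/kg, with a likely range from 7 mL/min/kg to 40 mL/min/kg.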

Compound 4, clearance: 50 mL/min/kg
Compound 4: middle estimate off by 3.3-fold (0.52 log units), on the low side; the whole stated range lies below it.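

In this assay, methyl in place of hydrogen on a saturated ring carbon gives a 1.5-fold higher number from compound 3 to compound 4 (0.18 log units; within the scatter), so compound 3 and compound 4 cannot be placed in any order in this assay. Among these compounds, the clear lowering seen on the core of compound 2 therefore does not carry over to the core of compound 3, and the size of the step depends on the core that receives the methyl: the same change on two cores in this assay, a 4.0-fold lower number (0.60 log units; beyond the scatter) from compound 2 to compound 1 and a 1.5-fold higher number (0.18 log units; within the scatter) from compound 3 to compound 4, 6.0-fold (0.78 log units) apart, beyond the scatter of two such steps These two pairs show only that a step measured on one core is not a safe guide to the other; they are too few to give a rule, and they do not tell which difference between the two cores separates the steps.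

The compounds shown leave open whether a longer chain or an amine in place of the methyl on that saturated ring carbon would also act differently on the two cores. They also leave open whether the same split between the cores would hold with a nitrile in place of trifluoromethyl.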